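The source may hold more compounds than are shown below. What is called first, only, known or untested is meant among the compounds shown, and "the series" means these compounds.

Two compounds of the series have a number in a functional assay on CHO cells for agonist activity at Free fatty acid receptor 1 (Homo sapiens); on this read-out lower numbers stand for an effect already at smaller amounts and higher numbers for an effect only at larger amounts of compound. Compound 1 `Cc1nc(-c2ccc(C(F)(F)F)cc2)sc1CNc1ccc([C@H]2C[C@@H]2C(=O)N(C)C)cc1` gives 66.1 nM in this assay. Compound 2 `Cc1nc(-c2ccc(C(F)(F)F)cc2)sc1CNc1ccc([C@H]2C[C@@H]2C(=O)N[C@H](C)c2ccccc2)cc1` gives 53.7 nM in this assay, the lowest of the two numbers, though its gap to compound 1 lies within the scatter. Going by the values given here, the one step available, a 1.2-fold lower number from compound 1 to compound 2 (0.09 log units; within the scatter), exchanges the substituent on the amide-type nitrogen and stays within the scatter.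

Compound 3 `Cc1nc(-c2ccc(C(F)(F)F)cc2)sc1CNc1ccc([C@H]2C[C@@H]2C(=O)NO)cc1` differs from compound 2 at that same amide-type nitrogen: hydroxy in place of 1-phenylethyl on an amide-type nitrogen. The measured step bears on it only in that it touches the same place; it gives no direction, and neither of the two amines measured resembles a hydroxy group with one donor and one acceptor. Among the compounds with values here, the data therefore hold no precedent for this substituent.

Because a 1.2-fold lower number from compound 1 to compound 2 (0.09 log units; within the scatter) is within the scatter, tolerance at this nitrogen is shown only for the two amines measured, and for compound 3 a moderate rise in the number is expected, a 3.0-fold higher number from compound 2 to compound 3 (0.47 log units; beyond the scatter). In this assay compound 3 is estimated at 160 nM, with a range from 50 nM to 600 nM.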

Compound 3, half-maximal effective concentration: 6.92 nM
Compound 3: the middle estimate sits 23-fold (1.36 log units) above what was measured; the whole stated range lies above it.
By their numbers in this assay, from the lowest: compound 3; then compounds 2 and 1 (each within the scatter of the next).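

Going by these compounds alone, at the amide-type nitrogen the choice of substituent now matters in this assay: hydroxy in place of 1-phenylethyl gives a 7.8-fold lower number from compound 2 to compound 3 (0.89 log units; beyond the scatter), and hydroxyamino in place of dimethylamino on the carbonyl carbon gives a 9.6-fold lower number from compound 1 to compound 3 (0.98 log units; beyond the scatter), whereas the only earlier step at this place stayed within the scatter. The aromatic ring and the defined stereocentre of 1-phenylethyl both leave in the change to hydroxy, and the number still falls, so neither feature is required for a low number in this series. The data at hand offer no evidence that explains the size of these steps.

How a methoxy group on this nitrogen, an unsubstituted carboxamide or a carboxylic acid in place of the hydroxycarbamoyl group would read remains open, so the compounds shown do not separate hydroxy from other small groups at this place. As far as these compounds go, all three compounds share one core, and whether the step holds on any other core is equally open.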